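This account rests on a few compounds, and the source may have more. Where it says the series, first, only, none or still open, it means among the compounds named here.

Of the compounds shown here, two built on a shared core have been measured in a functional assay on SK-MEL-28 cells (Homo sapiens) for antiproliferative activity, read by sulforhodamine B assay, with a stated time of 48 h; on this read-out higher numbers stand for weaker inhibition and lower numbers for stronger inhibition. Compound 1 `COc1cc(-c2nn(-c3ccc(NC(=O)Nc4ccc(Cl)c(Cl)c4)cc3)cc2-c2ccncc2)ccc1Cl` gives 3940 nM. Compound 2 `COc1cc(-c2nn(-c3ccc(NC(=O)c4ccc(Cl)c(C(F)(F)F)c4)cc3)cc2-c2ccncc2)ccc1Cl` gives 2800 nM. Among the two numbers compound 2 stands at the lower one, but the step of a 1.4-fold lower number from compound 1 to compound 2 (0.15 log units; within the scatter) lies within the scatter, so the two cannot be told apart on this read-out.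

Compound 3 `O=C(Nc1ccc(-n2cc(-c3ccncc3)c(-c3ccc(Cl)c(O)c3)n2)cc1)c1ccc(Cl)c(C(F)(F)F)c1` has not been measured. It differs from compound 2 in a single place: hydrogen in place of methyl on an oxygen on an aromatic ring. Within the data shown here, the one measured step, a 1.4-fold lower number from compound 1 to compound 2 (0.15 log units; within the scatter), concerns the group on the carbonyl carbon at the other end of the molecule and says nothing about trading methoxy for hydroxy. Among the measured compounds shown here, no measured pair shows what that exchange does here. With nothing pointing either way, the expected step is no change at the digits printed from compound 2 to compound 3 (within the scatter), a change that stays within the scatter. On these data alone, compound 3 is therefore estimated at 2800 nM, with a range from 1000 nM to 8000 nM, the width of that range reflecting that the exchange is untested.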

Compound 3, half-maximal inhibitory concentration: 1080 nM
Beside the measured number, compound 3's estimate is 2.6-fold (0.41 log units) above it, within the range that was stated.
By their numbers in this assay, from the lowest: compound 3; then compounds 2 and 1 (each within the scatter of the next).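

In this assay, among these compounds, trading methoxy for hydroxy on the 4-chloro-3-methoxyphenyl group gives a 2.6-fold lower number from compound 2 to compound 3 (0.41 log units; beyond the scatter) and is the first change in this small set to move the number beyond the scatter. The earlier step, a 1.4-fold lower number from compound 1 to compound 2 (0.15 log units; within the scatter), concerned the group on the carbonyl carbon and could not be told apart from repeat-measurement noise, whereas this one shows that removing only a methyl from an oxygen on an aromatic ring can register on this read-out, though the effect is modest and rests on a single pair. No measurement offered here explains why the number falls with this exchange.

The pair cannot show whether the gain comes from the free hydroxy or simply from losing the methyl, and an amine or an ethoxy at this place would help separate those two readings. Among the compounds shown here, it also remains open whether the same exchange would act alike on compound 1, which carries (3,4-dichlorophenyl)amino on the carbonyl carbon, since this step has been seen only with the 4-chloro-3-(trifluoromethyl)phenyl group there.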